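Chain extension on the fluoro analogue: expected inhibition

The compounds below may be only part of what the source reports. "The series", "measured", "known", "first", "only" and "open" are said of these compounds alone.

Compound 1 `CCc1cc2ccccc2nc1-c1cc(-c2ccccc2)no1` in a functional assay on COLO 205 cells (Homo sapiens) for inhibition, read by MTT assay, with a stated time of 24 h (on this read-out lower numbers stand for stronger inhibition and higher numbers for weaker inhibition), gives > 100000 nM, which is a limit of the assay.
Compound 2 `CCCc1cc2ccccc2nc1-c1cc(-c2ccccc2)no1` in this assay gives 48900 nM.
Compound 3 `CCc1cc2ccccc2nc1-c1cc(-c2ccc(F)cc2)no1` in this assay gives > 100000 nM, which is a limit of the assay.

Compound 3 thus stands only at the limit of > 100000 nM in this assay, at which 2 of the 3 values shown sit, and the step that the two limits leave unreadable from compound 1 to compound 3 is unreadable for that reason. Compound 4 `CCCc1cc2ccccc2nc1-c1cc(-c2ccc(F)cc2)no1` has not been measured; it differs from compound 3 by methyl in place of hydrogen on a saturated chain carbon, two bonds along the chain from an aromatic carbon. Going by the values given here, the one measured step with the same change is an at least 2.0-fold lower number from compound 1 to compound 2 (0.31 log units; beyond the scatter), which starts from a limit and gives only a lower bound for the gain. The expected step for compound 4 is an at least 2.0-fold lower number from compound 3 to compound 4 (0.30 log units; that floor lies within the scatter) in this assay, towards stronger inhibition. The estimate for compound 4 in this assay is 50000 nM, within 20000 nM to 120000 nM.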

Compound 4, half-maximal inhibitory concentration: 50300 nM
Compound 4: the middle estimate sits 1.0-fold (0.00 log units) below what was measured, within the range that was stated.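

The methyl on this chain carbon now gives an at least 1.9-fold lower number from compound 3 to compound 4 (0.29 log units; that floor lies within the scatter), so the lower number seen on the core of compound 1 also appears with the fluoro group present, though the size of the step is only a floor. The two cores can only be compared as far as the limits allow: the same change on two cores in this assay, an at least 2.0-fold lower number (0.31 log units; beyond the scatter) from compound 1 to compound 2 and an at least 1.9-fold lower number (0.29 log units; that floor lies within the scatter) from compound 3 to compound 4; the limit leaves it open whether they differ

With the propyl chain in place, the fluoro group becomes readable in this assay, as a 1.0-fold higher number from compound 2 to compound 4 (0.01 log units; within the scatter), which leaves the two propyl compounds within the scatter.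

The true size of both chain steps stays open, as each starts from a limit: the limit of > 100000 nM in this assay, at which 2 of the 4 values shown sit.

From the compounds shown here alone, whether a butyl chain at this carbon would take the number lower also remains open.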